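The source may report more compounds than this note shows. Statements on the series, on what has been measured and on what is new or still open speak of the compounds shown alone.

Compound 2 `CCOC(=O)C12C(=O)OCC=C1COC2c1ccco1` is one of two compounds that have been measured in a functional assay on A549 cells (Homo sapiens) for cytotoxicity, read by MTT assay; on this read-out lower numbers stand for stronger inhibition and higher numbers for weaker inhibition. In this assay compound 2 gives > 1000000 nM, which is a limit of the assay rather than a number. Compound 1 `CCOC(=O)C12C(=O)OCC=C1COC2c1ccc(Cl)cc1` likewise gives > 1000000 nM, also a limit. The step that the two limits leave unreadable from compound 1 to compound 2 is thus unreadable in size. Compound 3 `CCOC(=O)C12C(=O)OCC=C1COC2c1ccccn1` differs from compound 2 by pyridin-2-yl in place of furan-2-yl on a saturated ring carbon. No readable step bears on this change, since both values shown sit at the limit of > 1000000 nM in this assay, at which 2 of the 2 values shown sit. Compound 3 is therefore estimated at 1000000 nM, within 200000 nM to 3000000 nM. The expected step is a number no higher from compound 2 to compound 3 (the limit leaves the size open), nothing beyond the scatter.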

Compound 3, half-maximal inhibitory concentration: > 1000000 nM
Compound 3 was reported as a limit; the forecaster's own chance of this, stated with the estimate: 80%; the middle value sits exactly at the limit.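

No step can be read among compound 1, compound 2 and compound 3 in this assay, because all three values are limits: the limit of > 1000000 nM in this assay, at which 3 of the 3 values shown sit. The compounds shown leave open whether changing the group on the saturated ring carbon alters the read-out at all.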